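Long chains and amides on a shared triazole core

The source may hold more compounds than are shown below. What is called first, only, known or untested is meant among the compounds shown, and "the series" means these compounds.

Measured compounds:
- compound 1, `O=c1c2ccc(C(F)(F)F)nc2ncn1Cc1cc(-c2ccc(Cl)cc2)no1`: 840 nM
- compound 2, `CCCCCCCCn1cc(Cn2c(CC)nc3nc(C(F)(F)F)ccc3c2=O)nn1`: 1270 nM
- compound 3, `O=C(Cn1cc(COc2nc(-c3ccccc3)nc3nc(C(F)(F)F)ccc23)nn1)Nc1ccccc1`: 890 nM

All three compounds were tested in a functional assay on HeLa cells (Homo sapiens) for antiproliferative activity, read by sulforhodamine B assay, with a stated time of 48 h; on this read-out lower numbers stand for stronger inhibition of growth and higher numbers for weaker inhibition of growth. Compound 3, with a structure of `O=C(Cn1cc(COc2nc(-c3ccccc3)nc3nc(C(F)(F)F)ccc23)nn1)Nc1ccccc1`, gives 890 nM in this assay. Among the three numbers it stands second highest, yet its gaps to both neighbours are small: compound 1 gives a slightly lower value with 840 nM, and compound 2 a slightly higher one with 1270 nM, and both of these gaps fall within the usual scatter of repeated measurements. On the numbers shown, then, the three compounds cannot be told apart.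

Compound 4, `CCCCCCCCCCn1cc(COc2nc(-c3ccccc3)nc3nc(C(F)(F)F)ccc23)nn1`, has not yet been measured in this assay. It differs from compound 3 in one place: nonyl in place of phenylcarbamoyl on a saturated chain carbon bound to an aromatic nitrogen. In other words, a phenylcarbamoyl group is exchanged for a nonyl chain on the saturated chain carbon bound to the aromatic nitrogen, so that a hydrogen-bond donor and acceptor leave and a plain hydrocarbon chain enters.

Among the compounds with values here, no pair of measured compounds differs in exactly this way, so the size of the step cannot be read directly from the data. The closest hint is compound 2, which also carries a long alkyl chain on its triazole and gives 1270 nM, a value within the scatter of compound 3. The expected step from compound 3 to compound 4 is therefore a 1.1-fold higher number from compound 3 to compound 4 (0.05 log units; within the scatter), which is to say no change beyond the scatter. Compound 4 is estimated at 1000 nM, with a likely range from 400 nM to 2500 nM.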

Compound 4, concentration for 50% growth inhibition: 1040 nM
Compound 4: the middle estimate sits 1.0-fold (0.02 log units) below what was measured; the range from low to high includes it.
By their numbers in this assay, from the lowest: compounds 1, 3, 4 and 2 (each within the scatter of the next).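

In this assay, within the data shown here, the exchange of phenylcarbamoyl for nonyl gives a 1.2-fold higher number from compound 3 to compound 4 (0.07 log units; within the scatter) and so offers the first direct look at a change on this saturated chain carbon bound to an aromatic nitrogen: the two compounds cannot be told apart. The group that leaves brings an aromatic ring, a double bond outside aromatic rings, a hydrogen-bond donor and a hydrogen-bond acceptor, whereas the nonyl chain brings none of these, yet losing them all together leaves the number within the usual scatter in this one pair. No measurement at hand explains why the number holds steady.

On these data alone, a single exchange cannot show how much freedom this place allows, so it remains open whether a chain ending in an amine or a carboxylic acid, or a chain longer than decyl, would also leave growth inhibition unchanged. As far as these compounds go, it is also open whether the same exchange would give a similar step on a different core, such as the core of compound 2.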